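Side-chain variation on the shared core: compound 3 to compound 4

The source may report more compounds than this note shows. Statements on the series, on what has been measured and on what is new or still open speak of the compounds shown alone.

Three compounds with the same core and different chains on the aromatic nitrogen have been measured in a functional assay on A-375 cells (Homo sapiens) for cytotoxicity, read by MTT assay, with a stated time of 72 h; on this read-out lower numbers stand for stronger inhibition and higher numbers for weaker inhibition. Compound 1 `O=C1c2c[n+]([O-])c3ccccc3c2C(=O)c2c1c1ccccc1n2Cc1cn(CC(O)CO)nn1` gives 440 nM. Compound 2 `O=C1c2c[n+]([O-])c3ccccc3c2C(=O)c2c1c1ccccc1n2CCCCN1CCNCC1` gives 460 nM. Compound 3 `CN1CCN(CCCn2c3c(c4ccccc42)C(=O)c2c[n+]([O-])c4ccccc4c2C3=O)CC1` gives 470 nM. Compound 3 stands within the scatter of both others: a 1.1-fold higher number from compound 1 to compound 3 (0.03 log units; within the scatter) and a 1.0-fold higher number from compound 2 to compound 3 (0.01 log units; within the scatter); likewise a 1.0-fold higher number from compound 1 to compound 2 (0.02 log units; within the scatter). Across these three, swapping the whole chain or only its end group has not moved the read-out beyond the scatter.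

Compound 4 `CCCN1CCN(CCCCn2c3c(c4ccccc42)C(=O)c2c[n+]([O-])c4ccccc4c2C3=O)CC1` is the next member. Relative to compound 3, the change is (4-propylpiperazin-1-yl)methyl in place of 4-methylpiperazin-1-yl on a saturated chain carbon, three bonds along the chain from an aromatic nitrogen. Within the data shown here, the one measured step that bears directly on it is the swap at the same place between compound 2 and compound 3, a 1.0-fold higher number from compound 2 to compound 3 (0.01 log units; within the scatter), which lengthens the chain by one carbon and alters the piperazine; the steps from compound 1, a 1.0-fold higher number from compound 1 to compound 2 (0.02 log units; within the scatter) and a 1.1-fold higher number from compound 1 to compound 3 (0.03 log units; within the scatter), replace the entire chain and also stay within the scatter. Among the measured compounds shown here, nothing among the measured steps points to a direction, so for compound 4 no step beyond the scatter in this assay is expected, no change at the digits printed from compound 3 to compound 4 (within the scatter). Compound 4 is estimated at 470 nM, with a range from 230 nM to 950 nM.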

Compound 4, half-maximal inhibitory concentration: 870 nM
Estimate against measurement, compound 4: 1.9-fold (0.27 log units) below; measured number inside the range.
By their numbers in this assay, from the lowest: compounds 1, 2, 3 and 4 (each within the scatter of the next).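

Working notes on the chain. In this assay, among these compounds, propyl in place of hydrogen on an amine nitrogen in a ring gives a 1.9-fold higher number from compound 2 to compound 4 (0.28 log units; within the scatter); this is the first step that alters only that ring nitrogen and leaves the chain length unchanged. The wider change, (4-propylpiperazin-1-yl)methyl in place of 4-methylpiperazin-1-yl on a saturated chain carbon, gives a 1.9-fold higher number from compound 3 to compound 4 (0.27 log units; within the scatter), and 3-(4-propylpiperazin-1-yl)propyl in place of 1-(2,3-dihydroxypropyl)-1H-1,2,3-triazol-4-yl gives a 2.0-fold higher number from compound 1 to compound 4 (0.30 log units; within the scatter), so the propyl group adds a third kind of end-group change to the series and all four chains still remain unseparated by this read-out. No measurement available here bears on the size of these steps.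

Open, going by these compounds, is the separate contribution of chain length and propyl in the step from the 2-(4-methylpiperazin-1-yl)ethyl chain to the 3-(4-propylpiperazin-1-yl)propyl chain, which a 3-(4-methylpiperazin-1-yl)propyl chain would divide. Also open, on these data alone, is whether a butyl or benzyl group on the ring nitrogen, or a chain ending in a morpholine or a carboxylic acid, would give a step beyond the scatter.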